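The source may report more compounds than this note shows. Statements on the series, on what has been measured and on what is new or still open speak of the compounds shown alone.

In a functional assay on cells (T-cell line, Homo sapiens) for inhibition (a higher number here means a weaker inhibitor, a lower number a stronger inhibitor), compound 1 `CN1CCC(COC(c2ccccc2)c2ccccc2)CC1` gives > 20000 nM, which is a limit of the assay and not a number. Compound 2 `Clc1ccc(CCCN2CCC(COC(c3ccccc3)c3ccccc3)CC2)cc1` gives 500 nM and compound 3 `CCCCCCCN1CCC(COC(c2ccccc2)c2ccccc2)CC1` gives 500 nM, so these two stand level, with no change at the digits printed from compound 2 to compound 3 (within the scatter). Both departures from compound 1 were large: an at least 40-fold lower number from compound 1 to compound 2 (1.60 log units; beyond the scatter), and an at least 40-fold lower number from compound 1 to compound 3 (1.60 log units; beyond the scatter). Compound 4 `C(#Cc1ccccc1)CN1CCC(COC(c2ccccc2)c2ccccc2)CC1` differs from compound 3 by 2-phenylethynyl in place of hexyl on a saturated chain carbon bound to an amine nitrogen in a ring, with 2-phenylethynyl in place of hexyl on a saturated chain carbon bound to an amine nitrogen in a ring. The aromatic ending of compound 2 read the same as the butyl ending of compound 3, so no step beyond the scatter is expected in this assay. The expected step is a 1.2-fold higher number from compound 3 to compound 4 (0.08 log units; within the scatter). Compound 4 is estimated at 600 nM, within an expected range of 200 nM to 2500 nM.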

Compound 4, half-maximal inhibitory concentration: > 20000 nM
Compound 4 was reported as a limit (the forecaster's own chance of this, stated with the estimate: 8%); middle value at least 33-fold (1.52 log units) from the limit.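

Ending length alone does not set the result at this position, on a saturated chain carbon bound to an amine nitrogen in a ring: 2-phenylethynyl in place of hexyl gives an at least 40-fold higher number from compound 3 to compound 4 (1.60 log units; beyond the scatter), and in place of 2-(4-chlorophenyl)ethyl it gives an at least 40-fold higher number from compound 2 to compound 4 (1.60 log units; beyond the scatter). So an aromatic ending is not enough when the chain carries a triple bond, and the value of compound 4 is a limit of the assay. The step between compound 1 and compound 4 cannot be read, because both stand at a limit: the limit of > 20000 nM in this assay, at which 2 of the 4 values shown sit.

As far as these compounds go, whether a 3-phenylpropyl ending, or a double bond in place of the triple bond, would restore inhibition remains open.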